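Replacing iodo with dimethylcarbamoyl on the fused core

The source may report more compounds than this note shows. Statements on the series, on what has been measured and on what is new or still open speak of the compounds shown alone.

Three compounds have been measured in a functional assay on CHO cells for antagonist activity at Orexin receptor type 2 (Homo sapiens), read by FLIPR and calcium flux; a higher number here means a weaker inhibitor, a lower number a stronger inhibitor:

Compound 1 `CNC(=O)[C@@H](c1ccccc1)N1CCn2c(COC)nc(Cl)c2[C@@H]1CCc1ccc(C(F)(F)F)cc1` gives 25 nM in this assay.
Compound 2 `CCOc1nc(CC)n2c1C(CCc1ccc(C(F)(F)F)cc1)N([C@@H](C(=O)NC)c1ccccc1)CC2` gives 2750 nM in this assay.
Compound 3 `CCc1nc(I)c2n1CCN([C@@H](C(=O)NC)c1ccccc1)C2CCc1ccc(C(F)(F)F)cc1` gives 23 nM in this assay.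

Compound 3 has the lowest number of the three, but its gap to compound 1 lies within the scatter, so the two cannot be ordered. Among the compounds with values here, compound 2 stands far apart, and the one measured step that connects it to the core of compound 3 is a 120-fold lower number from compound 2 to compound 3 (2.08 log units; beyond the scatter).

Compound 4 `CCc1nc(C(=O)N(C)C)c2n1CCN([C@@H](C(=O)NC)c1ccccc1)C2CCc1ccc(C(F)(F)F)cc1` differs from compound 3 in one place: dimethylcarbamoyl in place of iodo on an aromatic carbon. Within the data shown here, no measured pair shows a carbamoyl entering at this position, so the step from compound 2 to compound 3 is the only one that bears on the change, and it only shows that iodo at this carbon went with a far lower number than ethoxy. A group other than a halogen at this carbon has so far been accompanied by a much higher number, and the expectation is therefore that compound 4 moves in the same direction as compound 2, though with wide uncertainty in size: the estimated step is an 11-fold higher number from compound 3 to compound 4 (1.04 log units; beyond the scatter). Compound 4 is thus expected to give 250 nM in this assay, within a range from 40 nM to 1600 nM.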

Compound 4, half-maximal inhibitory concentration: 111 nM
Compound 4: middle estimate off by 2.3-fold (0.35 log units), on the high side; the measured number falls inside the stated range.
By their numbers in this assay, from the lowest: compounds 3 and 1 (each within the scatter of the next); then compound 4; then compound 2.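

In this assay, the step to the dimethylcarbamoyl group is only modest, at a 4.8-fold higher number from compound 3 to compound 4 (0.68 log units; beyond the scatter), even though this group brings five heavy atoms to the aromatic carbon in place of the single iodine atom. The same group stands well apart from ethoxy, with a 25-fold lower number from compound 2 to compound 4 (1.39 log units; beyond the scatter), so the large penalty seen with ethoxy does not follow from the loss of iodo alone. At this position on the shared core, the group that enters matters, and the three compounds that differ only here give separate results, with iodo lowest, dimethylcarbamoyl in the middle and ethoxy highest. Nothing available explains why the dimethylcarbamoyl group falls between the other two.

The compounds shown leave open which part of the dimethylcarbamoyl group goes with its distance from iodo, and a primary carboxamide, a carboxylic acid or a nitrile on this carbon would help to separate the carbonyl from the two methyl groups. As far as these compounds go, it also remains open whether the same order of the three groups would hold with a longer chain in place of the ethyl group.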